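Benzyl for bromo on the aryl amide of compound 3

The compounds below may be only part of what the source reports. "The series", "measured", "known", "first", "only" and "open" are said of these compounds alone.

Compound 3 `C[C@H](NC(=O)C(=O)Nc1ccccc1Br)C(=O)N[C@@H](CC(=O)O)C(=O)COc1c(F)c(F)cc(F)c1F` is the strongest inhibitor of the three measured compounds in a functional assay on THP-1 cells (Homo sapiens) for inhibition (a lower number here means a stronger inhibitor, a higher number a weaker inhibitor), where compound 3 gives 50 nM. Its nearest neighbour is compound 2 `C[C@H](NC(=O)C(=O)Nc1ccccc1F)C(=O)N[C@@H](CC(=O)O)C(=O)COc1c(F)c(F)cc(F)c1F`, which gives 160 nM in this assay, and the furthest is compound 1 `C[C@H](NC(=O)C(=O)NC1CCCCC1)C(=O)N[C@@H](CC(=O)O)C(=O)COc1c(F)c(F)cc(F)c1F`, which gives 500 nM. Compound 4 `C[C@H](NC(=O)C(=O)Nc1ccccc1Cc1ccccc1)C(=O)N[C@@H](CC(=O)O)C(=O)COc1c(F)c(F)cc(F)c1F` has not yet been measured in this assay; it differs from compound 3 by benzyl in place of bromo on an aromatic carbon.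

All three measured steps touch this same position. The step of a 3.1-fold lower number from compound 1 to compound 2 (0.49 log units; beyond the scatter) and the step of a 10-fold lower number from compound 1 to compound 3 (1.00 log units; beyond the scatter) show that an aromatic ring in place of the saturated ring lowers the number, and the step of a 3.2-fold lower number from compound 2 to compound 3 (0.51 log units; beyond the scatter) shows that the heavier halogen at this position lowers it further. Benzyl extends this series of changes at the same carbon, but no measured compound carries a group of this kind there, so the direction rests on only two points.

He therefore expects a small step, a 1.3-fold lower number from compound 3 to compound 4 (0.10 log units; within the scatter), from compound 3 to compound 4, perhaps within the scatter. Compound 4 is estimated at 40 nM in this assay, in a range from 12 nM to 150 nM.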

Compound 4, half-maximal inhibitory concentration: 540 nM
Compound 4: middle estimate off by 14-fold (1.13 log units), on the low side; measured number above the stated range.
By their numbers in this assay, from the lowest: compound 3; then compound 2; then compounds 1 and 4 (each within the scatter of the next).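

In this assay, the rise in strength seen on going from fluoro to bromo on this aromatic carbon does not extend to benzyl: the change gives an 11-fold higher number from compound 3 to compound 4 (1.03 log units; beyond the scatter), and replacing the fluoro gives a 3.4-fold higher number from compound 2 to compound 4 (0.53 log units; beyond the scatter), so both halogen compounds stand well ahead of the benzyl compound. The earlier gain from an aromatic ring on the amide nitrogen also turns out to depend on what that ring carries, since compound 4 keeps such a ring, yet compound 4 at 540 nM lies within the scatter of compound 1 at 500 nM, which carries cyclohexyl, and so goes against any general benefit of the aromatic ring. Nothing available accounts for this loss of strength at the position.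

The compounds shown leave open whether a chloro, methyl or ethyl group on this carbon would stay with the halogens or fall with benzyl. They also leave open whether a phenyl group, without the linking carbon of benzyl, or a benzyl carrying an amine or a carboxylic acid, would recover any of the lost strength.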